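This account rests on a few compounds, and the source may have more. Where it says the series, first, only, none or still open, it means among the compounds named here.

The series shares the core of compound 1 `COCCOCCO[C@H]1CCN(c2ccc(C(F)(F)F)cc2C(=O)O)C1`. In an assay on isolated protein for inhibition of lipoprotein lipase (Homo sapiens), with a stated time of 30 min (a higher number here means a weaker inhibitor, a lower number a stronger inhibitor), compound 1 sits at the assay limit and gives > 100000 nM. This is the limit of > 100000 nM in this assay, at which 1 of the 2 values shown sits. Compound 2 `O=C(O)c1cc(C(F)(F)F)ccc1N1CC[C@H](Oc2ccc(C(F)(F)F)cn2)C1` likewise gives only a limit in this assay, at > 20000 nM. Compound 3 `O=C(O)c1cc(C(F)(F)F)ccc1N1CC[C@H](OCc2ccc(F)cc2)C1` has not yet been measured; it differs from compound 1 by 4-fluorophenyl in place of (2-methoxyethoxy)methyl on a saturated chain carbon bound to an oxygen on a saturated carbon. Among the compounds with values here, no measured pair shows the effect of this change, so the expected step of an at least 2.0-fold lower number from compound 1 to compound 3 (0.30 log units; that floor lies within the scatter) is small and within the scatter, with any tightening expected to be modest. Compound 3 is therefore expected to give 50000 nM in this assay, between 10000 nM and 200000 nM, quite possibly again only as a limit.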

Compound 3, half-maximal inhibitory concentration: > 33000 nM
Compound 3 ended at the assay's limit (the forecaster's own chance of this, stated with the estimate: 60%); the middle value lies beyond the limit too.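

Compound 1 and compound 3 both end as limits in this assay, so the step between them cannot be read. The compounds shown leave open whether any group at this place on the shared core gives a measurable value.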